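The compounds below may be only part of what the source reports. "The series", "measured", "known", "first", "only" and "open" are said of these compounds alone.

Measured compounds in the series:
- compound 1, `CCCCCOc1ccc([C@@H]2CC(=O)c3c(OC)cc(OCCCCC)c(CC=C(C)C)c3O2)cc1`, 8.2 ug/mL
- compound 2, `C=CCOc1ccc([C@@H]2CC(=O)c3c(OC)cc(OCC=C)c(CC=C(C)C)c3O2)cc1`, 6.2 ug/mL

Both numbers come from a functional assay on HT-29 cells (Homo sapiens) for antiproliferative activity, read by sulforhodamine B assay, with a stated time of 72 h; a higher number here means a weaker inhibitor, a lower number a stronger inhibitor. In this assay compound 1 gives 8.2 ug/mL, the higher of the two values shown, while compound 2 gives 6.2 ug/mL; the gap between the two lies within the scatter of the measurement, so no order between them can be read from these numbers.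

Compound 3, `CCCCCOc1cc(OC)c2c(c1CC=C(C)C)O[C@H](c1ccc(O)cc1)CC2=O`, is not yet measured in this assay. Compared with compound 1 it differs in one place: hydrogen in place of pentyl on an oxygen on an aromatic ring. Cut one bond further out, the same difference reads pentyloxy to hydroxy on the phenyl.

Going by the values given here, no step between two measured compounds is known here, so there is no direct reference for the size of this change. The expectation is a step from compound 1 to compound 3 of a 1.2-fold higher number from compound 1 to compound 3 (0.09 log units; within the scatter), no larger than the scatter. For compound 3 the estimated value in this assay is 10 ug/mL, with a range from 4 ug/mL to 25 ug/mL.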

Compound 3, concentration for 50% inhibition: 6.9 ug/mL
Estimate against measurement, compound 3: 1.4-fold (0.16 log units) above; the measured number falls inside the stated range.
By their numbers in this assay, from the lowest: compounds 2, 3 and 1 (each within the scatter of the next).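

In this assay, going by these compounds alone, this is the first step read at this position: hydrogen in place of pentyl on an oxygen on an aromatic ring gives a 1.2-fold lower number from compound 1 to compound 3 (0.07 log units; within the scatter), which lies within the scatter. The 4-(pentyloxy)phenyl and the 4-hydroxyphenyl therefore cannot be told apart here, with the pentyloxy on the core unchanged in both compounds. Nothing at hand bears on why this change leaves the two numbers within the scatter.

From the compounds shown here alone, it remains open whether a different group on this oxygen, such as a longer chain, a carboxylic acid or an amine, would give a step beyond the scatter. Going by these compounds, it is also open whether the same change at the pentyloxy on the core would read the same way.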